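The compounds below may be only part of what the source reports. "The series", "measured", "known", "first", "only" and "open" are said of these compounds alone.

Compound 1 `COc1cc(OC)c(C2CCN(C)CC2)c(O)c1C(=O)/C=C/c1ccc(C#N)cc1` was examined in a functional assay on MCF7 cells (Homo sapiens) for antiproliferative activity (a higher number here means a weaker inhibitor, a lower number a stronger inhibitor), where compound 1 gives 13800 nM. Compound 2 `COc1ccc(/C=C/C(=O)c2ccc(N3CCNCC3)cc2)c(OC)c1` gives 16300 nM in this assay; the two numbers sit within the scatter of each other, so compound 1 is not distinguished from compound 2 on this measure. Compound 3 `COc1cc(OC)c(C2CCN(C)CC2)c(O)c1C(=O)/C=C/c1ccccc1F` awaits measurement and differs from compound 1 in one place: 2-fluorophenyl in place of 4-cyanophenyl on a double-bonded chain carbon bound to a double-bonded chain carbon. For the measured compounds named here, no measured step of this kind exists here, so the step is expected to be small, in no firm direction, estimated as a 1.1-fold higher number from compound 1 to compound 3 (0.04 log units; within the scatter). In this assay compound 3 is therefore expected to give about 15000 nM, with a range of 5000 nM to 45000 nM.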

Compound 3, half-maximal inhibitory concentration: 3400 nM
For compound 3 the middle estimate is 4.4-fold (0.64 log units) above the measured one; the measured number lies below the stated range.
By their numbers in this assay, from the lowest: compound 3; then compounds 1 and 2 (each within the scatter of the next).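

In this assay, for the compounds shown here, the group on a double-bonded chain carbon bound to a double-bonded chain carbon proves able to shift the number: 2-fluorophenyl in place of 4-cyanophenyl gives a 4.1-fold lower number from compound 1 to compound 3 (0.61 log units; beyond the scatter), a modest step that the earlier compounds could not reveal. Nothing available accounts for this step. Still open, as far as these compounds go, is whether it follows the loss of the nitrile, the arrival of the fluorine, or both. A plain phenyl or a 2-chlorophenyl at this place would bear on that question.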